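A few compounds are considered here, and "the series" means these few. Any claim that something is new, unique, unknown or untested is made for them only; others in the source may bear on it.

Compound 1 `COc1cc2c(=O)c(C(=O)c3ccc(C)cc3)cn(Cc3ccc(Cl)cc3)c2cc1OC` — 15500 nM
Compound 2 `CN1CCN(c2cc3c(cc2F)c(=O)c(NC(=O)NCc2ccc(Cl)cc2)cn3Cc2ccc(Cl)cc2)CC1` — "not active" (no number reported)
Compound 3 `COc1cc2c(=O)c(S(=O)(=O)CCc3ccc(Cl)cc3)cn(Cc3ccccc3)c2cc1OC` — "not active" (no number reported)

For the measured compounds named here, in an ADME assay on Huh-7 cells (Homo sapiens) for cytotoxicity (a lower number here means a stronger inhibitor of growth, a higher number a weaker inhibitor of growth), compound 1 gives 15500 nM, the only number in the set; compound 2 returns "not active" (no number reported), and compound 3 returns "not active" (no number reported), so no step between measured compounds can be drawn. Compound 4 `COc1cc2c(=O)c(C(=O)c3ccc(C)cc3)cn(CC3CCCCC3)c2cc1OC` is the untested partner of compound 1 and differs from it by cyclohexyl in place of 4-chlorophenyl on a saturated chain carbon bound to an aromatic nitrogen. Going by the values given here, with no measured step to lean on, the change from 4-chlorophenyl to cyclohexyl on the saturated chain carbon bound to the aromatic nitrogen is expected to leave the value of compound 1 largely unchanged, within or close to the usual scatter, if anything toward a slightly weaker inhibitor of growth, and the expected step is a 1.3-fold higher number from compound 1 to compound 4 (0.11 log units; within the scatter). Compound 4 is accordingly estimated at 20000 nM, with a range from 7000 nM to 60000 nM.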

Compound 4, concentration for 50% growth inhibition: 22000 nM
For compound 4 the middle estimate is 1.1-fold (0.04 log units) below the measured one; the measured number falls inside the stated range.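

In this assay, for the compounds shown here, the change from 4-chlorophenyl to cyclohexyl gives a 1.4-fold higher number from compound 1 to compound 4 (0.15 log units; within the scatter) and so provides the first step that can be read at this position. Here, on a saturated chain carbon bound to an aromatic nitrogen, a non-aromatic ring without chlorine keeps the number within the scatter of the 4-chlorobenzyl compound. Nothing measured here accounts for this result. From the compounds shown here alone, whether an amine, a carboxylic acid or a longer chain at this place would shift the number beyond the scatter remains open, as does whether this swap behaves alike on other cores.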